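Dimethylamino in place of ethyl on an aromatic carbon

A few compounds are considered here, and "the series" means these few. Any claim that something is new, unique, unknown or untested is made for them only; others in the source may bear on it.

Of the compounds shown here, two have numbers so far in a physicochemical assay for solubility, at pH 6.8; a higher number here means a more soluble compound, a lower number a less soluble compound. Compound 1 (`Nc1cc(C(F)(F)F)c(Br)nc1C(=O)NC[C@@H](O)C(F)(F)F`) gives 177 ug/mL, and compound 2 (`CCc1nc(C(=O)NCC(C)(O)C(F)(F)F)c(N)cc1C(F)(F)F`) gives 91 ug/mL, which lies within the usual scatter of the other number. The next compound, compound 3 (`CN(C)c1nc(C(=O)NCC(C)(O)C(F)(F)F)c(N)cc1C(F)(F)F`), has dimethylamino in place of ethyl on an aromatic carbon, next to the ring nitrogen, ortho to a trifluoromethyl group and para to an amino group: dimethylamino in place of ethyl on an aromatic carbon. Within the data shown here, no measured pair shows this exchange, so nothing yet tells how it plays out in this assay. The estimated change, a 1.1-fold lower number from compound 2 to compound 3 (0.06 log units; within the scatter), is small and is expected to stay within the scatter, with no clear direction. Compound 3 is expected at 80 ug/mL, with an estimated range of 30 ug/mL to 200 ug/mL.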

Compound 3, solubility: 165 ug/mL
Beside the measured number, compound 3's estimate is 2.1-fold (0.31 log units) below it; measured number inside the range.
By their numbers in this assay, from the lowest: compounds 2, 3 and 1 (each within the scatter of the next).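

In this assay, among these compounds, the exchange of ethyl for dimethylamino gives a 1.8-fold higher number from compound 2 to compound 3 (0.26 log units; within the scatter) and this is the first measured pair to show it. At this aromatic carbon, next to the ring nitrogen and ortho to a trifluoromethyl group, the two groups therefore cannot be told apart in this read-out, and this one pair sets no direction for the exchange. Nothing measured here accounts for the step.

From the compounds shown here alone, whether the same holds for other groups on this carbon, such as a methoxy group, a morpholine ring or a carboxylic acid, stays open. Compound 1 differs from compound 3 in more than one place, so it cannot show whether the exchange would read the same with bromine at this position or with a different side chain.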